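Moving One Fluorine: From Compound 2 to Compound 3

A few compounds are considered here, and "the series" means these few. Any claim that something is new, unique, unknown or untested is made for them only; others in the source may bear on it.

In a functional assay on HeLa cells (Homo sapiens) for cytotoxicity, read by MTT assay, with a stated time of 48 h (on this read-out higher numbers stand for weaker inhibition and lower numbers for stronger inhibition), compound 1 `C=C1OC(=O)C=C1Cc1ccc(NC(=O)/C=C/c2ccccc2)cc1` gives 7340 nM and compound 2 `C=C1OC(=O)C=C1Cc1ccc(NC(=O)/C=C/c2cccc(F)c2)cc1` gives 30200 nM, the higher of the two numbers and so the weaker inhibition. Compound 3 `C=C1OC(=O)C=C1Cc1ccc(NC(=O)/C=C/c2ccccc2F)cc1` has the same atoms as compound 2, joined differently: 2-fluorophenyl in place of 3-fluorophenyl on a double-bonded chain carbon bound to a double-bonded chain carbon. Within the data shown here, the only measured step that bears on this is a 4.1-fold higher number from compound 1 to compound 2 (0.61 log units; beyond the scatter), a modest one, with fluoro in place of hydrogen on an aromatic carbon. Among the measured compounds shown here, no measured compound carries the 2-fluorophenyl group, so this guide is loose. A modest move to a lower number is expected, a 2.0-fold lower number from compound 2 to compound 3 (0.30 log units; within the scatter). For compound 3 the estimate is 15000 nM, with an expected range of 5000 nM to 40000 nM.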

Compound 3, half-maximal inhibitory concentration: 6930 nM
Compound 3: middle estimate off by 2.2-fold (0.34 log units), on the high side, and the stated range covers the measured number.
By their numbers in this assay, from the lowest: compounds 3 and 1 (each within the scatter of the next); then compound 2.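

In this assay the place of the fluorine counts: 2-fluorophenyl in place of 3-fluorophenyl brings a 4.4-fold lower number from compound 2 to compound 3 (0.64 log units; beyond the scatter) with no atom gained or lost. Set against the compound without fluorine, 2-fluorophenyl shows a 1.1-fold lower number from compound 1 to compound 3 (0.02 log units; within the scatter) and so, among these three compounds, the weaker result appears only with 3-fluorophenyl. No measurement at hand explains this difference. Still open, from the compounds shown here alone, is whether 4-fluorophenyl in the same place would track compound 2 or compound 3. Also open, going by these compounds, is whether 2-chlorophenyl or 2-methoxyphenyl would match 2-fluorophenyl.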